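This account rests on a few compounds, and the source may have more. Where it says the series, first, only, none or still open, it means among the compounds named here.

Compound 1 `CCN(CC)S(=O)(=O)c1ccc(S(=O)(=O)N2CCC[C@@H](C(=O)N3CC[C@@H](OC)C3)C2)cc1`: 1070 nM
Compound 2 `CCN(CC)S(=O)(=O)c1ccc(S(=O)(=O)N2CCC[C@@H](C(=O)N[C@@H]3CCOC3)C2)cc1`: 100 nM
Compound 3 `CCN(CC)S(=O)(=O)c1ccc(S(=O)(=O)N2CCC[C@@H](C(=O)N3CCC(OC)CC3)C2)cc1`: 50 nM

Of the compounds shown here, three sharing one core have been measured in a functional assay on MIA PaCa-2 cells (Homo sapiens) for inhibition, read by MTT assay, with a stated time of 3 days; on this read-out lower numbers stand for stronger inhibition and higher numbers for weaker inhibition. Compound 1 gives 1070 nM, compound 2 gives 100 nM and compound 3 gives 50 nM. Compound 3 gives the lowest of the three numbers, though its gap to compound 2 lies within the scatter, while compound 1 sits well apart. The steps of an 11-fold lower number from compound 1 to compound 2 (1.03 log units; beyond the scatter) and a 21-fold lower number from compound 1 to compound 3 (1.33 log units; beyond the scatter) show that the group on the carbonyl carbon can shift the number a great deal, whereas a 2.0-fold lower number from compound 2 to compound 3 (0.30 log units; within the scatter) is small.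

Compound 4 `CCN(CC)S(=O)(=O)c1ccc(S(=O)(=O)N2CCC[C@@H](C(=O)N3CCC(C(F)F)CC3)C2)cc1` has not yet been measured. Within the data shown here, it differs from compound 3 in one place: difluoromethyl in place of methoxy on a saturated ring carbon None of the measured steps changes a substituent on the six-membered ring itself; each replaces the whole group on the carbonyl carbon, so no measured step bears directly on this change. Compound 3 is therefore the anchor, and no step beyond the scatter is expected in this assay. The expected step is a 1.2-fold higher number from compound 3 to compound 4 (0.08 log units; within the scatter). Compound 4 is estimated at 60 nM, with a range from 20 nM to 200 nM.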

Compound 4, half-maximal inhibitory concentration: 140 nM
Beside the measured number, compound 4's estimate is 2.3-fold (0.37 log units) below it; the range from low to high includes it.
By their numbers in this assay, from the lowest: compounds 3, 2 and 4 (each within the scatter of the next, the first and the last beyond it); then compound 1.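

In this assay, the substituent on the saturated ring carbon, three ring bonds from the ring nitrogen, matters in its own right: difluoromethyl in place of methoxy gives a modest step beyond the scatter (a 2.8-fold higher number from compound 3 to compound 4 (0.45 log units; beyond the scatter)), whereas each earlier step replaced the whole group on the carbonyl carbon. The 4-(difluoromethyl)piperidin-1-yl group still keeps much of the gain over 3-methoxypyrrolidin-1-yl (a 7.6-fold lower number from compound 1 to compound 4 (0.88 log units; beyond the scatter)), and it cannot be separated from the (oxolan-3-yl)amino group, the gap staying within the scatter (a 1.4-fold higher number from compound 2 to compound 4 (0.15 log units; within the scatter)). Nothing available accounts for the step at this position.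

From the compounds shown here alone, whether a hydroxyl, a single fluorine or a methyl on the same ring carbon would give a number nearer compound 3 or compound 4 remains open. So does whether a longer ether chain there would hold up.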